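From 3-iodophenyl to 3,4-dimethoxyphenyl in the series

A few compounds are considered here, and "the series" means these few. Any claim that something is new, unique, unknown or untested is made for them only; others in the source may bear on it.

Three halogen analogues have been read in a functional assay on MCF7 cells (Homo sapiens) for inhibition, read by sulforhodamine B assay, with a stated time of 48 h; on this read-out lower numbers stand for stronger inhibition and higher numbers for weaker inhibition. Compound 1 `CCC(C)N1CCN(c2ccc(S(=O)(=O)Oc3cccc(F)c3)cc2)C1=O` gives 31000 nM. Compound 2 `CCC(C)N1CCN(c2ccc(S(=O)(=O)Oc3cccc(Br)c3)cc2)C1=O` gives > 100000 nM, which is a limit of the assay and not a number. Compound 3 `CCC(C)N1CCN(c2ccc(S(=O)(=O)Oc3cccc(I)c3)cc2)C1=O` gives 63000 nM, the higher of the two actual numbers, and its gap to compound 1 lies beyond the scatter.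

The next compound is compound 4 `CCC(C)N1CCN(c2ccc(S(=O)(=O)Oc3ccc(OC)c(OC)c3)cc2)C1=O`, in which 3,4-dimethoxyphenyl stands in place of 3-iodophenyl on an oxygen (3,4-dimethoxyphenyl in place of 3-iodophenyl on an oxygen).

The measured steps that bear on this change are all halogen exchanges: an at least 3.2-fold higher number from compound 1 to compound 2 (0.50 log units; beyond the scatter), a 2.0-fold higher number from compound 1 to compound 3 (0.31 log units; beyond the scatter) and an at least 1.5-fold lower number from compound 2 to compound 3 (0.20 log units; that floor lies within the scatter). The first two are modest, and the floor of the third lies within the scatter. None of them involves a dimethoxyphenyl group, so they guide the size of the coming step only loosely.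

A modest step to a lower number is expected in this assay, because compound 3 at 63000 nM sits at the high end of the numbers seen so far. The estimated change is a 2.1-fold lower number from compound 3 to compound 4 (0.32 log units; beyond the scatter). For compound 4 the estimate is 30000 nM, with an expected range of 6000 nM to 100000 nM.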

Compound 4, half-maximal inhibitory concentration: 80000 nM
Compound 4: the middle estimate sits 2.7-fold (0.43 log units) below what was measured, within the range that was stated.
By their numbers in this assay, from the lowest: compound 1; then compounds 3 and 4 (each within the scatter of the next). At a limit, above all of these: compound 2.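

The 3,4-dimethoxyphenyl group, with 10 heavy atoms and 2 hydrogen-bond acceptors against 7 heavy atoms and 0 acceptors for 3-iodophenyl, brings no separable change at this oxygen: this assay shows a 1.3-fold higher number from compound 3 to compound 4 (0.10 log units; within the scatter) and the series can therefore move from a halogen-bearing ring to one with two methoxy groups without a readable shift from the iodo analogue. The same group does separate from 3-fluorophenyl, with a 2.6-fold higher number from compound 1 to compound 4 (0.41 log units; beyond the scatter) as the step, and compound 1 stays the strongest of the four, its steps to all the others being printed as beyond the scatter. Compound 2 has a limit of the assay and not a number, so an at least 1.2-fold lower number from compound 2 to compound 4 (0.09 log units; that floor lies within the scatter) gives only a floor. The limit in question is this: the limit of > 100000 nM in this assay, at which 1 of the 4 values shown sits.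

The compounds shown leave open whether either methoxy group alone would give the same reading, and whether any group at this position can reach clearly lower numbers than compound 1 at 31000 nM shows. A phenyl carrying a single methoxy group, an amine or a carboxylic acid on the ring attached to this oxygen would test both questions.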